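The compounds below may be only part of what the source reports. "The series", "measured", "known", "first", "only" and "open" are said of these compounds alone.

Of the compounds shown here, three that share one core have been tested in a functional assay on A549 cells (Homo sapiens) for cytotoxicity, read by MTT assay, with a stated time of 72 h; a higher number here means a weaker inhibitor, a lower number a stronger inhibitor. Compound 1 (`COc1cccc(/C=C2\CCC/C(=C\c3cccc(Cl)c3)C2=O)c1OC`) gives > 20000 nM as a limit, not a number. Compound 2 (`COc1ccc(/C=C2\CCC/C(=C\c3cccc(OC)c3OC)C2=O)c(OC)c1`) gives > 20000 nM as a limit too. Compound 3 (`COc1ccc(/C=C2\CCC/C(=C\c3ccccc3Cl)C2=O)cc1OC`) gives > 20000 nM as a limit again. Compound 3 thus sits at the limit of > 20000 nM in this assay, at which 3 of the 3 values shown sit, and has no exact value of its own.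

Compound 4 (`COc1cccc(/C=C2\CCC/C(=C\c3ccc(OC)c(OC)c3)C2=O)c1`) has not been measured yet. It carries 3-methoxyphenyl in place of 2-chlorophenyl on a double-bonded chain carbon bound to a double-bonded ring carbon. Among the compounds with values here, the swap adds one hydrogen-bond acceptor, but no measured pair here shows what a single change of this kind does, so any expectation is loose.

With compound 3 at > 20000 nM as a limit, compound 4 is expected to stay weak as well. The estimated step of an at least 1.2-fold lower number from compound 3 to compound 4 (0.09 log units; that floor lies within the scatter) is expected to be small, with no move in either direction beyond the usual scatter of repeat measurements. For compound 4 the estimated value is 16000 nM with an expected range from 6000 nM to 30000 nM and a good chance of only a limit once more.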

Compound 4, half-maximal inhibitory concentration: 6700 nM
Estimate against measurement, compound 4: 2.4-fold (0.38 log units) above; the measured number falls inside the stated range.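

In this assay, within the data shown here, replacing 2-chlorophenyl with 3-methoxyphenyl on a double-bonded chain carbon bound to a double-bonded ring carbon gives an at least 2.9-fold lower number from compound 3 to compound 4 (0.47 log units; beyond the scatter), the only step that can be read between compounds differing in one place. Compound 4, at 6700 nM, is also the only compound shown with an exact number, so the group at this place on the shared core can change the result in this cell test. The full size of the step remains unknown, since compound 3 has only a limit and the step therefore gives a minimum rather than an exact difference: the limit of > 20000 nM in this assay, at which 3 of the 4 values shown sit.

This single swap removes a chlorine-bearing ring and brings in a methoxy-bearing one, so the compounds shown cannot tell whether losing the chlorine, gaining the methoxy or both accounts for the change. A plain phenyl at this place would help separate those two parts, while a phenyl carrying an amine or a carboxylic acid would show how far the result depends on the kind of group the ring carries.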